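Ester for acid: the step from compound 3 to compound 4

The source may report more compounds than this note shows. Statements on the series, on what has been measured and on what is new or still open speak of the compounds shown alone.

Compound 3 `Cc1c(OCCCCOc2ccc(C(=O)O)cc2Cl)ccc(C(=O)CC(C)C)c1O` gives 99.5% in an assay on HEK293 cells for positive allosteric modulation of metabotropic glutamate receptor 2 (Rattus norvegicus), read by thallium flux, with a stated time of 2.5 min (on this read-out lower numbers stand for smaller maximal responses and higher numbers for larger maximal responses), the highest of three numbers. Among the measured compounds shown here, compound 1 `Cc1c(OCCCCOc2ccccc2C(=O)O)ccc(C(=O)CC(C)C)c1O` gives 92.4%, and the only one-place step, a number 7.1 percentage points higher from compound 1 to compound 3 (within the scatter), lies within the scatter. Compound 2 `COC(=O)c1ccc(OCCCCOc2ccc(C(=O)CC3CCCC3)c(O)c2C)cc1` gives 12.2%, far below compound 3. Compound 4 `COC(=O)c1ccc(OCCCCOc2ccc(C(=O)CC(C)C)c(O)c2C)cc1` is reached by 4-(methoxycarbonyl)phenyl in place of 4-carboxy-2-chlorophenyl on an oxygen on a saturated carbon. For the measured compounds named here, no measured step touches this change directly; the acid-to-ester swap is not isolated anywhere. Yet compound 2, the only measured ester, shows a very small maximal response, so a large drop from compound 3 is expected, estimated as a number 69.5 percentage points lower from compound 3 to compound 4 (beyond the scatter). Compound 4 is therefore estimated at 30%, expected between 8% and 75%, with wide uncertainty because compound 2 gives 12.2% while differing in a second place.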

Compound 4, largest response reached (reported as percent of maximum), in percent of the reference or control that the assay uses: 16.4%
Compound 4: the middle estimate sits 13.6 percentage points above what was measured; low and high end bracket the measured number.
By their numbers in this assay, from the lowest: compounds 2 and 4 (each within the scatter of the next); then compounds 1 and 3 (each within the scatter of the next).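

In this assay, 4-(methoxycarbonyl)phenyl on the oxygen on a saturated carbon takes away most of the response seen with either acid-bearing group, with a number 83.1 percentage points lower from compound 3 to compound 4 (beyond the scatter) and a number 76 percentage points lower from compound 1 to compound 4 (beyond the scatter). Isopropyl in place of cyclopentyl leaves the two esters within the scatter, with a number 4.2 percentage points higher from compound 2 to compound 4 (within the scatter), so the low response holds with either group on the chain. Nothing measured here explains the drop. Going by these compounds, compound 3 also carries a chlorine that compound 4 lacks, so the share of the ester alone stays open. On these data alone, how a 4-carboxyphenyl without chlorine, or an amide in place of the ester, would read also remains open.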